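Urea series: pyridinylpiperazinyl replaces cyclopropylamino

The compounds below may be only part of what the source reports. "The series", "measured", "known", "first", "only" and "open" are said of these compounds alone.

Among the compounds with values here, compound 3 `Cc1cc(Cl)ccc1NC(=O)Nc1nc(NC2CC2)cc(Sc2c[nH]c3ccccc23)n1` gives 31500 nM in a functional assay on A549 cells (Homo sapiens) for inhibition, with a stated time of 72 h (on this read-out higher numbers stand for weaker inhibition and lower numbers for stronger inhibition), the only actual number among the three measured members. Compound 2 `Cc1cc(Cl)ccc1NC(=O)Nc1nc(Nc2ccccc2)cc(Sc2c[nH]c3ccccc23)n1` reaches only the limit > 50000 nM in this assay. Compound 1 `COc1ccc(NC(=O)Nc2nc(Sc3c[nH]c4ccccc34)cc(N3CCN(c4ccccn4)CC3)n2)cc1` likewise stops at the limit > 50000 nM. Within the data shown here, the single measured step is an at least 1.5-fold lower number from compound 2 to compound 3 (0.20 log units; that floor lies within the scatter), whose floor lies within the scatter. Compound 4 `Cc1cc(Cl)ccc1NC(=O)Nc1nc(Sc2c[nH]c3ccccc23)cc(N2CCN(c3ccccn3)CC2)n1` carries the change (4-(pyridin-2-yl)piperazin-1-yl in place of cyclopropylamino on an aromatic carbon). Among the measured compounds shown here, no measured step addresses this exchange directly; what bears on it is that compound 1 already carries 4-(pyridin-2-yl)piperazin-1-yl and shows only a limit, and that the series rests largely at the limit of > 50000 nM in this assay, at which 2 of the 3 values shown sit. Compound 4 is therefore expected to move back toward that limit, an expected step of a 1.9-fold higher number from compound 3 to compound 4 (0.28 log units; within the scatter). The estimate for compound 4 is 60000 nM, with a range from 25000 nM to 150000 nM.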

Compound 4, half-maximal inhibitory concentration: > 50000 nM
Compound 4 ended at the assay's limit; the forecaster's own chance of this, stated with the estimate: 70%; the middle value does not contradict the limit.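

In this assay, replacing cyclopropylamino with 4-(pyridin-2-yl)piperazin-1-yl at this position gives an at least 1.5-fold higher number from compound 3 to compound 4 (0.20 log units; that floor lies within the scatter), so no loss is established. Within the data shown here, this group now sits at a limit with both the 4-methoxyphenyl and 4-chloro-2-methylphenyl ureas, leaving cyclopropylamino in compound 3 as the only group with an actual number, and the series otherwise rests at one value: the limit of > 50000 nM in this assay, at which 3 of the 4 values shown sit. The steps joining compound 4 to compound 1 and compound 2 cannot be read, with a limit at both ends.

Open, as far as these compounds go, is whether piperazine with a free secondary amine, or morpholin-4-yl, at this position would give a number.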